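Thiophene in Place of Chlorophenyl on the Alkyne of Compound 3

The source may hold more compounds than are shown below. What is called first, only, known or untested is meant among the compounds shown, and "the series" means these compounds.

Of the compounds shown here, three have been measured in a functional assay on HEK293 cells for positive allosteric modulation of metabotropic glutamate receptor 5 (Homo sapiens), read by FLIPR and calcium flux; a higher number here means that more compound is needed for the effect, a lower number that less compound is needed. Compound 1 `O=C(NC1CCCC1)c1ccc(C#Cc2ccccc2)nc1` gives 19 nM. Going by the values given here, compound 2 `CC(C)NC(=O)c1ccc(C#Cc2ccccc2)nc1` gives 62 nM, and the only single-point step among the measured compounds is a 3.3-fold higher number from compound 1 to compound 2 (0.51 log units; beyond the scatter). Compound 3 `O=C1c2ccc(C#Cc3ccccc3Cl)nc2CCN1C1CCCC1` gives 393 nM, the highest of the three numbers: compound 2 is nearest to it and compound 1 furthest, both separated from it by more than the scatter.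

Compound 4 `O=C1c2ccc(C#Cc3cccs3)nc2CCN1C1CCCC1` has not yet been measured. It differs from compound 3 in one place: thiophen-2-yl in place of 2-chlorophenyl on a triple-bonded carbon. Among the compounds with values here, the single measured step alters the group on the amide-type nitrogen, not the ring on the alkyne, so it offers no guide to the size or direction of this change. Within the data shown here, the data hold no other pair in which the ring on the alkyne is the only difference. With nothing to point either way, compound 4 is expected to stay close to compound 3, and the uncertainty is wide.

Compound 4 is therefore estimated at 350 nM in this assay, with a range from 90 nM to 1400 nM. This estimate means an expected step of a 1.1-fold lower number from compound 3 to compound 4 (0.05 log units; within the scatter), not resolved beyond the scatter.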

Compound 4, half-maximal effective concentration: 12 nM
Estimate against measurement, compound 4: 29-fold (1.46 log units) above; the whole stated range lies above it.
By their numbers in this assay, from the lowest: compounds 4 and 1 (each within the scatter of the next); then compound 2; then compound 3.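

In this assay, going by these compounds alone, the ring on the alkyne proves to be a far stronger lever than anything the earlier compounds showed: thiophen-2-yl in place of 2-chlorophenyl on a triple-bonded carbon gives a 33-fold lower number from compound 3 to compound 4 (1.52 log units; beyond the scatter) as a large step, while the only earlier step, on the amide-type nitrogen, was the modest 3.3-fold higher number from compound 1 to compound 2 (0.51 log units; beyond the scatter) and no more. The cyclopentyl group and the rest of compound 3 stay as they were in compound 4, so this one position can carry a great part of the spread in numbers, and the 2-chlorophenyl group is clearly not needed for a low number on this core. Nothing available here explains the size of the step. 

From the compounds shown here alone, the swap changes several things at once, the ring size, the chlorine leaving and the sulfur entering, so it remains open which of them matters, and a plain phenyl ring or a furan ring on the alkyne of this same core would begin to separate them. Also open, going by these compounds, is whether a substituted thiophene, such as one carrying a methyl group, would hold the low number of compound 4 at 12 nM in this assay or lose it.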